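The source may hold more compounds than are shown below. What is called first, only, known or untested is meant among the compounds shown, and "the series" means these compounds.

Measured in an ADME assay on the whole organism (plasma, Mus musculus, strain CD-1) for protein binding, read by LC-MS, with a stated time of 24 h; on this read-out higher numbers stand for a larger free fraction and lower numbers for a smaller free fraction:
- compound 1 `Cc1noc(-c2ccc(O[C@H]3CCC[C@H](C(=O)O)C3)cc2)c1CNC(=O)OCCC(C)(C)C`: 0.004
- compound 2 `CN(C(=O)OCc1c(-c2ccc(O[C@H]3CCC[C@H](C(=O)O)C3)cn2)nnn1C)C1CCCC1`: 0.083
- compound 3 `Cc1cc(-c2nnn(C)c2COC(=O)N(C)CCC(C)C)ccc1O[C@H]1CCC[C@H](C(=O)O)C1`: 0.018

Compound 1 stands lowest of the three, beyond the scatter from both others. Compound 4 `Cc1noc(-c2ccc(O[C@H]3CCC[C@H](C(=O)O)C3)cc2)c1COC(=O)N(C)C1CCCC1` has not yet been measured. It differs from compound 1 by a group of 10 heavy atoms (7 carbon, 1 nitrogen, 2 oxygen; one five-membered non-aromatic ring of carbon only) in place of a group of 10 heavy atoms (7 carbon, 1 nitrogen, 2 oxygen; no ring), on a saturated chain carbon bound to an aromatic carbon: a group with one five-membered non-aromatic ring of carbon only replaces a group with no ring, on a saturated chain carbon bound to an aromatic carbon. Going by the values given here, no measured pair isolates this change. Compound 2, which gives 0.083, carries a ring of this kind on a different core, so a modest rise is expected in this assay. The expected move toward a larger free fraction is a 3.0-fold higher number from compound 1 to compound 4 (0.48 log units; beyond the scatter). For compound 4 the estimated value is 0.012, with an expected range of 0.005 to 0.03.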

Compound 4, unbound fraction: 0.006
The estimate for compound 4 lay 2.0-fold (0.30 log units) above the measured number, within the range that was stated.
By their numbers in this assay, from the lowest: compounds 1 and 4 (each within the scatter of the next); then compound 3; then compound 2.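

Read in this assay, placing the group with one five-membered non-aromatic ring of carbon only on a saturated chain carbon bound to an aromatic carbon, where a group with no ring stood, gives a 1.5-fold higher number from compound 1 to compound 4 (0.18 log units; within the scatter). On this core, the ring and the absence of the hydrogen-bond donor in the entering group therefore leave the two compounds indistinguishable in free fraction. No supporting data bear on this result.

Left open is whether a hydroxyl group or an amine on that ring would give a number beyond the scatter from compound 1. Also open, on these data alone, is whether the same exchange would give a similar step on another core.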